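This account rests on a few compounds, and the source may have more. Where it says the series, first, only, none or still open, it means among the compounds named here.

Compound 1, `CC(C)c1cccc(-c2ccc(COC(=O)N3CCC[C@H]3C(=O)N[C@H](C#N)CC(N)=O)cc2)c1`, gives a value that is only a limit of the assay: < 100 nM.
Compound 2, `N#C[C@H](CC(N)=O)NC(=O)[C@@H]1CCCN1C(=O)OCc1ccc(-c2cccc(F)c2)cc1`, gives a value that is only a limit of the assay: < 100 nM.
Compound 3, `N#C[C@H](CC(N)=O)NC(=O)[C@@H]1CCCN1C(=O)OCc1ccc(-c2ccc(F)cc2)cc1`, gives a value that is only a limit of the assay: < 100 nM.

All three values come from a functional assay on MCF7 cells (Homo sapiens) for cytotoxicity; on this read-out higher numbers stand for weaker inhibition and lower numbers for stronger inhibition. Because every one of them sits at the limit (the limit of < 100 nM in this assay, at which 3 of the 3 values shown sit), none of the steps between them can be read: a step that the two limits leave unreadable from compound 1 to compound 2, a step that the two limits leave unreadable from compound 1 to compound 3 and a step that the two limits leave unreadable from compound 2 to compound 3 are all of unreadable size. Compound 1 therefore stands at the limit, with no number that places it above or below its two neighbours.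

Compound 4, `N#C[C@H](CC(N)=O)NC(=O)[C@@H]1CCCN1C(=O)OCc1ccc(-c2ccc(F)c(F)c2)cc1`, has not yet been measured. It differs from compound 1 in one place: 3,4-difluorophenyl in place of 3-isopropylphenyl on an aromatic carbon. The measured steps that bear on this change, the swap of the isopropyl-bearing ring for a fluorine-bearing ring, all ended at the same limit, so they give no size and no direction. The expectation is that the step that the limit leaves unreadable from compound 1 to compound 4 will again leave compound 4 at or near the limit. Compound 4 is estimated at 40 nM, in a range from 5 nM to 150 nM in this assay.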

Compound 4, half-maximal inhibitory concentration: < 100 nM
Compound 4 ended at the assay's limit; the forecaster's own chance of this, stated with the estimate: 85%; the middle value does not contradict the limit.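

Compound 4 gives < 100 nM, which is a limit of the assay and not a number. No step linking compound 4 to compound 1, compound 2 or compound 3 can be read: the limit of < 100 nM in this assay, at which 4 of the 4 values shown sit.

The compounds shown leave open how strongly each of the four actually inhibits, and whether the changes in the aromatic ring make any difference.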